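This account rests on a few compounds, and the source may have more. Where it says the series, first, only, none or still open, it means among the compounds named here.

Measured compounds:
compound 1 `CO/N=C1\CC(CC(=O)O)c2ccc(OCc3cccc(-c4c(C)cc(OC)cc4C)c3)cc21` — > 1000 nM
compound 2 `CCOc1cc(C)c(-c2cccc(COc3ccc(S(=O)(=O)CC(=O)O)cc3)c2)c(C)c1` — 63.1 nM

In a functional assay on CHO cells for agonist activity at Free fatty acid receptor 1 (Homo sapiens), read by FLIPR and calcium flux (a lower number here means that less compound is needed, a higher number that more compound is needed for the effect), compound 1 gives > 1000 nM, which is a limit of the assay and not a number. For the measured compounds named here, compound 2 is the only compound with a measured number in this assay, where it gives 63.1 nM. Compound 3 `Cc1cc(OCC2CC2)cc(C)c1-c1cccc(COc2ccc(S(=O)(=O)CC(=O)O)cc2)c1` differs from compound 2 by cyclopropyl in place of methyl on a saturated chain carbon bound to an oxygen on an aromatic ring. No measured step of this kind is shown, so the change is expected to move this assay little, staying within or close to the usual scatter. Compound 3 is therefore estimated at 50 nM, ranging from 15 nM to 200 nM. The expected step is a 1.3-fold lower number from compound 2 to compound 3 (0.10 log units; within the scatter).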

Compound 3, half-maximal effective concentration: 79.4 nM
Estimate against measurement, compound 3: 1.6-fold (0.20 log units) below, within the range that was stated.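

In this assay, cyclopropyl in place of methyl on a saturated chain carbon bound to an oxygen on an aromatic ring gives a 1.3-fold higher number from compound 2 to compound 3 (0.10 log units; within the scatter). This first step between closely matched compounds shows that this assay does not separate ethoxy from the bulkier cyclopropylmethoxy, which adds a three-membered ring. Nothing measured here accounts for this outcome. As far as these compounds go, whether the same position would tolerate an amine, a hydroxyl group or a longer chain such as hexyl remains open.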